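Acetyl in Place of Hydrogen on the Aromatic Oxygen

The source may hold more compounds than are shown below. What is called first, only, known or untested is meant among the compounds shown, and "the series" means these compounds.

Compound 1 `C=CC[C@H]1C[C@]2([C@@H](C)Cc3ccccc3)OCOC2=CC1=O`: in a functional assay on NCI-H460 cells (Homo sapiens) for antiproliferative activity, with a stated time of 72 h (on this read-out higher numbers stand for weaker inhibition and lower numbers for stronger inhibition), compound 1 gives 9700 nM.
Compound 2 `C=CC[C@H]1C[C@]2([C@@H](C)Cc3ccc(O)cc3)OCOC2=CC1=O`: in this assay compound 2 gives > 20000 nM, a limit of the assay and not a number.

Compound 2 therefore stands only at a limit, reached through an at least 2.0-fold higher number from compound 1 to compound 2 (0.31 log units; beyond the scatter). Compound 3 `C=CC[C@H]1C[C@]2([C@@H](C)Cc3ccc(OC(C)=O)cc3)OCOC2=CC1=O` differs from compound 2 by acetyl in place of hydrogen on an oxygen on an aromatic ring. No measured step covers this change; the one step shown touches the same aromatic position and points to weaker inhibition, which leaves the direction of the new step open. In this assay compound 3 is expected near 15000 nM, between 5000 nM and 40000 nM. This estimate means an expected step of an at least 1.3-fold lower number from compound 2 to compound 3 (0.12 log units; that floor lies within the scatter), with a fair chance that only a limit is reported.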

Compound 3, half-maximal inhibitory concentration: > 20000 nM
Compound 3 ended at the assay's limit; the forecaster's own chance of this, stated with the estimate: 50%; middle value at least 1.3-fold (0.12 log units) away from the limit.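

The change from hydroxy to acetoxy returns no readable number in this assay, so the step between compound 2 and compound 3 cannot be read: the limit of > 20000 nM in this assay, at which 2 of the 3 values shown sit.

Acetoxy in place of hydrogen on the aromatic carbon gives an at least 2.0-fold higher number from compound 1 to compound 3 (0.31 log units; beyond the scatter). Weaker inhibition at this position therefore does not depend on a free hydroxy, since the acetoxy of compound 3 shows it as well.

Going by these compounds, how far compound 2 and compound 3 lie past the limit stays unknown, so no order between them can be given. On these data alone, whether an amine or a methoxy on this aromatic carbon would give a readable value in this assay also stays open.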